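A few compounds are considered here, and "the series" means these few. Any claim that something is new, unique, unknown or untested is made for them only; others in the source may bear on it.

Compound 1 `NC(=O)c1nc(N2CCN(C(=O)COc3ccc(Cl)cc3)CC2)c2cc(F)sc2n1` gives > 10000 nM in a functional assay on cells (Lymphocyte); on this read-out lower numbers stand for stronger inhibition and higher numbers for weaker inhibition. Compound 2 `Nc1nc(N2CCN(C(=O)C3CCCCC3)CC2)c2cc(F)sc2n1` gives > 10000 nM in this assay. Compound 3 `Nc1nc(N2CCN(C(=O)COc3ccc(F)cc3)CC2)c2ccsc2n1` gives 66 nM in this assay.

Going by the values given here, of the three results, only that of compound 3 is a number. The result for compound 1 is a limit of the assay, not a measured value. The result for compound 2 is likewise a limit. the limit of > 10000 nM in this assay, at which 2 of the 3 values shown sit, marks where two of the three results sit, so compound 3 stands alone as the compound with a measured potency, and no ordering among the three can be drawn beyond that.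

Compound 4 `Cc1cccc(NC(=O)N2CCN(c3nc(N)nc4sccc34)CC2)c1` has not yet been measured. It differs from compound 3 in one place: (3-methylphenyl)amino in place of (4-fluorophenoxy)methyl on a carbonyl carbon. Among the compounds with values here, no pair of measured compounds differs in a single place, so no measured step guides this change, and the shared core of compound 3 is kept. The expectation is that compound 4 stays close to compound 3 in this assay, the step of a 2.3-fold higher number from compound 3 to compound 4 (0.36 log units; beyond the scatter) being expected to lie near the scatter, with a modest weakening more likely than a gain. Compound 4 is therefore estimated at 150 nM, with a range from 30 nM to 1500 nM.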

Compound 4, half-maximal inhibitory concentration: 930 nM
Estimate against measurement, compound 4: 6.2-fold (0.79 log units) below; the range from low to high includes it.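

In this assay, (3-methylphenyl)amino in place of (4-fluorophenoxy)methyl on a carbonyl carbon gives a 14-fold higher number from compound 3 to compound 4 (1.15 log units; beyond the scatter), which shows that potency at this position responds strongly to the group carried there, although compound 4 still gives a measured number and not a limit. The two groups have the same kind of aromatic ring, but they differ in the atoms around it, and the entering group has a hydrogen-bond donor where the leaving group has an acceptor, so the step reflects several differences at once. No measured property shown here accounts for the size of this step.

As far as these compounds go, it remains open whether the weakening follows the linking atoms or the substituent on the ring. Pairing (4-fluorophenyl)amino or (3-methylphenoxy)methyl with the shared core would separate these two parts of the change.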